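The source may report more compounds than this note shows. Statements on the series, on what has been measured and on what is new or still open speak of the compounds shown alone.

Three compounds have so far been examined in an ADME assay on Vero cells (Chlorocebus sabaeus) for cytotoxicity, read by resazurin assay, with a stated time of 2 days; on this read-out higher numbers stand for lower toxicity in this test and lower numbers for higher toxicity in this test. Compound 1 `O=C(/C=C/c1ccc(NC(=O)Nc2ccc3ccccc3c2)cc1)C[C@@H]1O[C@H](CO)[C@@H](O)[C@H](O)[C@H]1O` gives 1020000 nM in this assay. Compound 2 `CC(=O)OC[C@H]1O[C@@H](CC(=O)/C=C/c2ccc(NC(=O)Nc3ccccc3)cc2)[C@H](OC(C)=O)[C@@H](OC(C)=O)[C@@H]1OC(C)=O` gives 820000 nM in this assay, a number that lies within the usual scatter of the value of compound 1, so the two cannot be told apart. Going by the values given here, compound 3 `CC(=O)O[C@@H]1[C@@H](OC(C)=O)[C@H](OC(C)=O)CO[C@H]1CC(=O)/C=C/c1cccc(NC(=S)Nc2ccccc2)c1` gives 58700 nM in this assay, a number well below that of compound 2 and beyond the scatter; compound 3 differs from compound 2 in more than one place, so the two values show only that these two compounds differ. Compound 4 `CC(=O)OC[C@H]1O[C@@H](CC(=O)/C=C/c2ccc(NC(=S)Nc3ccccc3)cc2)[C@H](OC(C)=O)[C@@H](OC(C)=O)[C@@H]1OC(C)=O` has not yet been measured. It differs from compound 2 by a group of 9 heavy atoms (7 carbon, 1 nitrogen, 1 sulfur; one six-membered aromatic ring of carbon only) in place of a group of 9 heavy atoms (7 carbon, 1 nitrogen, 1 oxygen; one six-membered aromatic ring of carbon only), on a nitrogen on an aromatic ring. Among the compounds with values here, no measured pair shows this change alone, so its effect in this assay is open. Within the data shown here, a moderate step toward a lower number is expected for compound 4, as the only measured compound carrying the entering group also gives the lowest number. Compound 4 is expected to give 300000 nM in this assay, estimated within a range from 80000 nM to 900000 nM. That estimate corresponds to an expected step of a 2.7-fold lower number from compound 2 to compound 4 (0.44 log units; beyond the scatter).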

Compound 4, half-maximal cytotoxic concentration: 663000 nM
Compound 4: middle estimate off by 2.2-fold (0.34 log units), on the low side; low and high end bracket the measured number.
By their numbers in this assay, from the lowest: compound 3; then compounds 4, 2 and 1 (each within the scatter of the next).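

In this assay, going by these compounds alone, placing the sulfur-bearing group on a nitrogen on an aromatic ring in place of phenylcarbamoyl gives a 1.2-fold lower number from compound 2 to compound 4 (0.09 log units; within the scatter), the first reading of this change on its own. On the core shared by these two compounds, the exchange of oxygen for sulfur thus leaves no difference that can be told from the scatter, so the entering group alone does not bring the number down to that of compound 3, at 58700 nM. Nothing at hand explains this result.

Going by these compounds, it remains open whether the same exchange would read alike on the cores of compound 1 or compound 3, and which of the several differences separates compound 3 from compound 4. The compounds also leave open what a methyl group or a longer alkyl chain carrying an amine would do on that nitrogen.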